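This account rests on a few compounds, and the source may have more. Where it says the series, first, only, none or still open, it means among the compounds named here.

Measured compounds:
compound 1, `C=C1C(=O)O[C@@H](c2ccccc2)[C@H]1C`, with 41% in a functional assay on BXPC-3 cells (Homo sapiens) for cytotoxicity, read by MTT assay, with a stated time of 72 h, tested at 10 uM; a lower number here means a stronger effect, a higher number a weaker effect of the compound at the concentration tested;
compound 2, `C=C1C(=O)O[C@@H](c2ccccc2)[C@H]1c1ccccc1`, with 8% in this assay.

Within the data shown here, compound 2 stands lowest of the two numbers in this assay; its nearest neighbour is compound 1, and the step of a number 33 percentage points lower from compound 1 to compound 2 (beyond the scatter) is the only measured step, and it lies beyond the scatter. That step replaces methyl with phenyl on a saturated ring carbon.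

The unmeasured compound 3, `C=C1C(=O)O[C@H](c2ccccc2)[C@H]1c1ccccc1`, is built from compound 2 by the two compounds have the same atoms and bonds and differ only in configuration as drawn: 1 of 2 stereo elements differ; a stereocentre at a saturated ring carbon is drawn R in compound 2 and S in compound 3. Among the measured compounds shown here, no measured step bears on such a change: the one step in hand, a number 33 percentage points lower from compound 1 to compound 2 (beyond the scatter), concerns an exchange of groups, not a change of configuration at a saturated ring carbon. There is therefore no measured basis for expecting a shift in either direction, and the expectation for compound 3 is a step of a number 7 percentage points higher from compound 2 to compound 3 (within the scatter) that stays within the scatter, with a wide uncertainty because nothing in the data speaks to configuration. The estimate for compound 3 in this assay is 15%, between 5% and 45%.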

Compound 3, a percentage reported as activity, at one concentration (the size of the read-out at that concentration, not a potency): 1%
Beside the measured number, compound 3's estimate is 14 percentage points above it; measured number below the stated range.
By their numbers in this assay, from the lowest: compounds 3 and 2 (each within the scatter of the next); then compound 1.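

This change tests configuration rather than an exchange of groups, and in this assay it gives a number 7 percentage points lower from compound 2 to compound 3 (within the scatter), so the two drawn forms at this saturated ring carbon cannot be told apart at the concentration tested. Among the compounds shown, only the exchange of methyl for phenyl on a saturated ring carbon, a number 33 percentage points lower from compound 1 to compound 2 (beyond the scatter), lies beyond the scatter, while this inversion of a single stereocentre does not. The pair isolates configuration at this one stereocentre, with the other stereo element and all the groups held constant: the fact that compounds 2 and 3 differ only in the configuration as drawn

Going by these compounds, what remains open is whether a change of configuration would also stay within the scatter with methyl on the saturated ring carbon, as in compound 1, and whether the second stereo element would behave in the same way. On these data alone, it is also open how an amine, a carboxylic acid or a longer alkyl chain in place of the phenyl group on that saturated ring carbon would read in this assay.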